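The source may hold more compounds than are shown below. What is called first, only, known or untested is meant among the compounds shown, and "the series" means these compounds.

Compound 1 `COc1cccc(-c2cc(C(=O)Nc3ccc(Oc4ccnc5cc(OCCCN6CCCCC6)c(OC)cc45)c(F)c3)c3ccccc3n2)c1`: 1740 nM
Compound 2 `COc1cc2c(Oc3ccc(NC(=O)c4cc(-c5ccc(Cl)c(Cl)c5)nc5ccccc45)cc3F)ccnc2cc1OCCCN1CCCC1`: 1960 nM

Both numbers come from a functional assay on HT-29 cells (Homo sapiens) for cytotoxicity, read by MTT assay, with a stated time of 72 h; a higher number here means a weaker inhibitor, a lower number a stronger inhibitor. Compound 2 holds the highest of the two numbers, but compound 1 lies within the scatter of it, so the two cannot be ordered. Compound 3 `COc1cccc(-c2cc(C(=O)Nc3ccc(Oc4ccnc5cc(OCCCN6CCCC6)c(OC)cc45)c(F)c3)c3ccccc3n2)c1` is not yet measured. It differs from compound 2 in one place: 3-methoxyphenyl in place of 3,4-dichlorophenyl on an aromatic carbon. Among the compounds with values here, no measured pair isolates this change, so its size is a matter of expectation. Because compound 1 also carries the 3-methoxyphenyl and gives 1740 nM, compound 3 is expected to show a step of a 1.1-fold lower number from compound 2 to compound 3 (0.04 log units; within the scatter) in this assay, within the scatter. The estimate for compound 3 is 1800 nM, ranging from 900 nM to 3600 nM.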

Compound 3, half-maximal inhibitory concentration: 1020 nM
Compound 3: middle estimate off by 1.8-fold (0.25 log units), on the high side; the range from low to high includes it.
By their numbers in this assay, from the lowest: compounds 3, 1 and 2 (each within the scatter of the next).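

In this assay, 3-methoxyphenyl in place of 3,4-dichlorophenyl on the aromatic carbon next to the ring nitrogen gives a 1.9-fold lower number from compound 2 to compound 3 (0.28 log units; within the scatter), so this change at this position is now isolated in one pair and cannot be told from repeat measurement. Pyrrolidin-1-yl in place of piperidin-1-yl on the chain can now also be read alone, giving a 1.7-fold lower number from compound 1 to compound 3 (0.23 log units; within the scatter), which likewise cannot be told from repeat measurement.

On these data alone, whether an unsubstituted phenyl at this position, or a morpholin-4-yl on the chain, would give a step beyond the scatter stays open. No measurement here offers an explanation for either step.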